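A few compounds are considered here, and "the series" means these few. Any claim that something is new, unique, unknown or untested is made for them only; others in the source may bear on it.

Of the compounds shown here, three have been measured so far. Compound 1 `O=C(CCCCC1CCSS1)Nc1ccccn1` and compound 2 `O=C(CCCCC1CCSS1)Nc1ccc(Cl)cn1` share one core; compound 3 `O=C(CCCCC(S)CCS)Nc1ccccc1` has a different core, and the difference between the two cores is not broken down here. In a functional assay on HO8910 cells (Homo sapiens) for inhibition, read by MTT assay, with a stated time of 24 h, tested at 100 ug/mL (a lower number here means less inhibition of growth, a higher number more inhibition of growth at the concentration tested), compound 1 gives 51.9%, and compound 2 gives 68.6%. The change between them is chloro in place of hydrogen on an aromatic carbon, and it gave a number 16.7 percentage points higher from compound 1 to compound 2 (beyond the scatter). Compound 3 gives 13.7% in this assay, the lowest of the three numbers. Compound 4 `O=C(CCCCC(S)CCS)Nc1ccc(Cl)cc1` is not yet measured; it arises from compound 3 by chloro in place of hydrogen on an aromatic carbon. Among the measured compounds shown here, this is the same kind of change as the one from compound 1 to compound 2, but the surroundings differ: in compound 2 the chloro sits on a ring with one nitrogen, two atoms from the ring nitrogen, whereas in compound 4 it sits on a ring of carbon only. Because a number 16.7 percentage points higher from compound 1 to compound 2 (beyond the scatter) was modest, the expected step is a number 12.3 percentage points higher from compound 3 to compound 4 (beyond the scatter). The estimated value for compound 4 in this assay is 26%, expected to fall between 10% and 45%.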

Compound 4, percent growth inhibition at one concentration: 21.3%
Compound 4: the middle estimate sits 4.7 percentage points above what was measured; measured number inside the range.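

Carried to the second core in this assay, chloro in place of hydrogen on an aromatic carbon gave a number 7.6 percentage points higher from compound 3 to compound 4 (within the scatter), so this step alone cannot be told apart from ordinary variation between repeated measurements. Set beside the earlier step, it does not differ measurably, and the data therefore give no sign that the core changes what this swap does: the same change on two cores in this assay, a number 16.7 percentage points higher (beyond the scatter) from compound 1 to compound 2 and a number 7.6 percentage points higher (within the scatter) from compound 3 to compound 4, 9.1 percentage points apart, within the scatter of two such steps. Among the compounds shown here, this does not show that the effect carries over reliably or keeps the same size, as only two pairs are compared, only one of the two steps stands clear of the scatter, and the chloro sits on a ring with one nitrogen in one pair and on a ring of carbon only in the other.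

The compounds shown leave open whether a methoxy group, an amine or a carboxylic acid in place of the chloro would behave alike on both cores. They also leave open how the two cores compare when they carry the same ring, since compound 1 and compound 3 differ in more than one place.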